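A few compounds are considered here, and "the series" means these few. Any claim that something is new, unique, unknown or untested is made for them only; others in the source may bear on it.

Measured compounds:
Compound 1 `CCCCc1ccc(CNS(=O)(=O)c2ccccc2)c(=O)n1Cc1ccc(-c2ccccc2-c2nn[nH]n2)cc1` — 7 nM in a functional assay (aorta) for antagonist activity, with Oryctolagus cuniculus as the target; a lower number here means a stronger inhibitor, a higher number a weaker inhibitor
Compound 2 `CCCCc1ccc(CNS(C)(=O)=O)c(=O)n1Cc1ccc(-c2ccccc2-c2nn[nH]n2)cc1` — 2 nM

For the measured compounds named here, compound 1 stands with the higher of the two numbers in this assay; the only measured step, a 3.5-fold lower number from compound 1 to compound 2 (0.54 log units; beyond the scatter), concerns the group on the sulfonyl sulfur. Compound 3 `CCCCc1ccc(CN(Cc2ccccc2)S(=O)(=O)c2ccccc2)c(=O)n1Cc1ccc(-c2ccccc2-c2nn[nH]n2)cc1` differs from compound 1 by benzyl in place of hydrogen on a sulfonamide nitrogen. Going by the values given here, no measured step touches the sulfonamide nitrogen, so the step from compound 1 to compound 2 bears on it only indirectly, showing that this region tolerates change. Compound 3 is estimated at 30 nM (range 6 nM to 150 nM), an expected step of a 4.3-fold higher number from compound 1 to compound 3 (0.63 log units; beyond the scatter); the expectation is weakly held.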

Compound 3, half-maximal inhibitory concentration: 20 nM
Beside the measured number, compound 3's estimate is 1.5-fold (0.18 log units) above it; the measured number falls inside the stated range.
By their numbers in this assay, from the lowest: compound 2; then compound 1; then compound 3.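

Placing benzyl on the sulfonamide nitrogen in this assay gives a 2.9-fold higher number from compound 1 to compound 3 (0.46 log units; beyond the scatter) and so costs a modest but real step. The hydrogen on that nitrogen is therefore not essential for inhibition in this series, and this first change at the nitrogen shows that a group as large as benzyl can be accommodated there. No evidence on the cause of this step is available.

Going by these compounds, whether methyl, a longer chain or a carboxylic acid on that nitrogen would do better remains open. Also open, on these data alone, is whether benzyl there has the same effect with methyl on the sulfonyl sulfur, as in compound 2.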